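The source may report more compounds than this note shows. Statements on the series, on what has been measured and on what is new or still open speak of the compounds shown alone.

Compound 1 `Cc1cccc(NC(=O)CN2CCC(c3ccccc3)CC2)c1`, compound 2 `Cc1cccc(NC(=O)CN2CCC(c3ccc(Cl)cc3)CC2)c1` and compound 3 `O=C(CN1CCN(c2ccccn2)CC1)Nc1cncnc1` were measured in an assay on HEK293 cells for displacement of a labelled ligand from D(4) dopamine receptor (Homo sapiens), read by scintillation counting, with a stated time of 60 min; on this read-out higher numbers stand for weaker inhibition and lower numbers for stronger inhibition. Compound 1 gives 25.8 nM, compound 2 gives 115 nM, and compound 3 gives 39300 nM. The change from compound 1 to compound 2 is chloro in place of hydrogen on an aromatic carbon, and it produced a 4.5-fold higher number from compound 1 to compound 2 (0.65 log units; beyond the scatter). The difference between the core of compound 1 and the core of compound 3 is not broken down here. Compound 4 `O=C(CN1CCN(c2ccc(Cl)cn2)CC1)Nc1cncnc1` differs from compound 3 by chloro in place of hydrogen on an aromatic carbon, the same kind of change, though here the ring is a six-membered aromatic ring with 1 nitrogen, two atoms from the ring nitrogen, rather than a ring of carbon only. Compound 4 is expected to show a 2.3-fold higher number from compound 3 to compound 4 (0.36 log units; beyond the scatter) in this assay because a 4.5-fold higher number from compound 1 to compound 2 (0.65 log units; beyond the scatter) went the same way. Compound 4 is therefore estimated at 90000 nM, between 30000 nM and 300000 nM.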

Compound 4, inhibition constant: > 50000 nM
Compound 4: a limit, no number; the forecaster's own chance of this, stated with the estimate: 35%; the middle value does not contradict the limit.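

In this assay compound 4 gives > 50000 nM, which is a limit of the assay and not a number. On the core of compound 3, the change from pyridin-2-yl to 5-chloropyridin-2-yl therefore gives only a floor, an at least 1.2-fold higher number from compound 3 to compound 4 (0.10 log units; that floor lies within the scatter), and this does not by itself establish a rise for the chloro group on this core. The result does not show whether the change carries over from the core of compound 1 with the same size: the same change on two cores in this assay, a 4.5-fold higher number (0.65 log units; beyond the scatter) from compound 1 to compound 2 and an at least 1.2-fold higher number (0.10 log units; that floor lies within the scatter) from compound 3 to compound 4; the limit leaves it open whether they differ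

The compounds shown leave open how a fluoro, methoxy or amino group on the same aromatic carbon would read on either core. They also leave open the size of the chloro step on the core of compound 3.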